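The source may hold more compounds than are shown below. What is called first, only, known or untested is meant among the compounds shown, and "the series" means these compounds.

Compound 1 `Cc1nc(-c2ccc(Cl)cc2)sc1C(=O)CSc1nc(-c2ccccc2)c(C#N)c(=O)[nH]1` gives 41.6%. Compound 2 `COc1ccc(-c2nc(C)c(C(=O)CSc3nc(-c4cccc(OC)c4)c(C#N)c(=O)[nH]3)s2)cc1` gives 43.2%. Compound 3 `COc1cccc(-c2nc(SCC(=O)c3sc(-c4ccccc4)nc3C)[nH]c(=O)c2C#N)c1` gives 80.3%.

In a functional assay on U-87MG ATCC cells for antiproliferative activity against U-87 MG (Homo sapiens), read by MTT assay, with a stated time of 48 h, tested at 50 uM (a higher number here means a weaker effect of the compound at the concentration tested, a lower number a stronger effect), compound 2 stands second highest of the three; its nearest neighbour is compound 1, within the scatter, and its furthest is compound 3. Compound 4 `COc1ccc(-c2nc(C)c(C(=O)CSc3nc(-c4ccccc4)c(C#N)c(=O)[nH]3)s2)cc1` differs from compound 2 by hydrogen in place of methoxy on an aromatic carbon. Among the measured compounds shown here, the only measured step of this kind, a number 37.1 percentage points higher from compound 2 to compound 3 (beyond the scatter), was large and upward, although it took the methoxy from the other aromatic ring of the molecule. For the measured compounds named here, compound 1 and compound 4 share a phenyl on the pyrimidinone side, yet no step between them is available. Compound 4 is therefore expected to move upward in this assay, a number 14.8 percentage points higher from compound 2 to compound 4 (beyond the scatter), with wide uncertainty. The estimate for compound 4 is 58%, ranging from 38% to 82%.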

Compound 4, a percentage reported as activity, at one concentration (the size of the read-out at that concentration, not a potency): 72.5%
For compound 4 the middle estimate is 14.5 percentage points below the measured one, and the stated range covers the measured number.
By their numbers in this assay, from the lowest: compounds 1 and 2 (each within the scatter of the next); then compounds 4 and 3 (each within the scatter of the next).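

In this assay, the change from 3-methoxyphenyl to phenyl also weakens the effect (a number 29.3 percentage points higher from compound 2 to compound 4 (beyond the scatter)), so losing the methoxy at this place raises the number, as losing the methoxy on the other aromatic ring did (a number 37.1 percentage points higher from compound 2 to compound 3 (beyond the scatter)). With this phenyl in place, the other ring's substituent matters too: methoxy in place of chloro also weakens the effect (a number 30.9 percentage points higher from compound 1 to compound 4 (beyond the scatter)). Nothing available explains these shifts.

Going by these compounds, whether chloro at the place of the methoxy in 3-methoxyphenyl would keep the stronger effect remains open. So does the outcome with an amine or a longer alkoxy chain there.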